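Oxygen Inserted in the Acid Chain of Compound 2

The compounds below may be only part of what the source reports. "The series", "measured", "known", "first", "only" and "open" are said of these compounds alone.

Compound 2 `O=C(O)CC/C=C1/C[C@H]2C[C@@H](O)[C@H](/C=N/NC(=O)Nc3ccc([N+](=O)[O-])cc3)[C@H]2C1` gives the lowest number of the three measured compounds in a functional assay on a cell-free system (plasma) for agonist activity at thromboxane A2 receptor (Homo sapiens) (a lower number here means a stronger inhibitor, a higher number a weaker inhibitor), namely 20 nM. Compound 1 `O=C(O)CC/C=C1/C[C@H]2C[C@@H](O)[C@H](/C=N/NC(=O)Nc3cccc(Cl)c3)[C@H]2C1` gives 600 nM, and compound 3 `O=C(O)CC/C=C1\C[C@H]2C[C@@H](O)[C@H](/C=N/NC(=O)Nc3ccc([N+](=O)[O-])cc3)[C@H]2C1` gives 520 nM. Both measured steps are large: a 30-fold lower number from compound 1 to compound 2 (1.48 log units; beyond the scatter) and a 26-fold higher number from compound 2 to compound 3 (1.41 log units; beyond the scatter), the latter resting on (the fact that compounds 2 and 3 differ only in the configuration as drawn). Compound 4 `O=C(O)COC/C=C1/C[C@H]2C[C@@H](O)[C@H](/C=N/NC(=O)Nc3ccc([N+](=O)[O-])cc3)[C@H]2C1` differs from compound 2 by carboxymethoxy in place of carboxymethyl on a saturated chain carbon bound to a double-bonded chain carbon. Neither measured step touches this part of the molecule, so they offer no direct guide, and the change itself is small. A step of a 2.0-fold higher number from compound 2 to compound 4 (0.30 log units; within the scatter) is therefore expected, likely within the scatter or only slightly weaker. Compound 4 is estimated to give 40 nM, with a range from 8 nM to 200 nM.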

Compound 4, half-maximal inhibitory concentration: 20 nM
Compound 4: middle estimate off by 2.0-fold (0.30 log units), on the high side; low and high end bracket the measured number.
By their numbers in this assay, from the lowest: compounds 2 and 4 (each within the scatter of the next); then compounds 3 and 1 (each within the scatter of the next).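

In this assay, the acid chain gains an oxygen with no measurable loss (no change at the digits printed from compound 2 to compound 4 (within the scatter)). Among these compounds, the earlier steps changed only the group on the amide-type nitrogen and the drawn double-bond configuration, so this is the first evidence that this chain position accepts carboxymethoxy in place of carboxymethyl. Nothing at hand explains this tolerance. Still open, going by these compounds, is whether a sulfur atom or an amine nitrogen in the same place would be accepted equally well. On these data alone, a longer chain carrying the carboxylic acid also remains untested here.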